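Isopropyl for methyl on the saturated ring: compound 4

The compounds below may be only part of what the source reports. "The series", "measured", "known", "first", "only" and "open" are said of these compounds alone.

Compound 1 `CC(C)C1CC(=O)c2s/c(=N/C3CCCCC3)oc2C1`: in a functional assay on NCI-H23 cells (Homo sapiens) for antiproliferative activity, read by sulforhodamine B assay (a higher number here means a weaker inhibitor of growth, a lower number a stronger inhibitor of growth), compound 1 gives 7080 nM.
Compound 2 `CC1(C)CC(=O)c2s/c(=N/c3c(Cl)cc(Cl)cc3Cl)oc2C1`: in this assay compound 2 gives > 30000 nM, a limit of the assay.
Compound 3 `CC1CC(=O)c2s/c(=N/c3c(Cl)cc(Cl)cc3Cl)oc2C1`: in this assay compound 3 gives > 30000 nM, a limit of the assay.

Compound 3 stands only at a limit in this assay, so no number is known for it. Compound 2 sits at the same limit, (the limit of > 30000 nM in this assay, at which 2 of the 3 values shown sit). The step that the two limits leave unreadable from compound 2 to compound 3 is therefore of unreadable size. Compound 4 `CC(C)C1CC(=O)c2s/c(=N/c3c(Cl)cc(Cl)cc3Cl)oc2C1` differs from compound 3 by isopropyl in place of methyl on a saturated ring carbon. Among the compounds with values here, no measured step bears directly on this change; the only step between measured compounds is the one between the two limits, and it gives no size. Within the data shown here, compound 1 also carries isopropyl on the saturated ring carbon but differs from compound 4 elsewhere, and no step between them is available. Nothing shown points to a move beyond the scatter, so compound 4 is expected to remain at or near the limit. The step that the limit leaves unreadable from compound 3 to compound 4 is expected to stay within the scatter. For compound 4 the estimated value is 40000 nM, with a range from 12000 nM to 150000 nM.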

Compound 4, concentration for 50% growth inhibition: > 30000 nM
Compound 4: only a limit was reported; the forecaster's own chance of this, stated with the estimate: 70%; the middle value is on the limit's open side.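

Compound 3 and compound 4 both stand only at a limit in this assay, so no step can be read between them: the limit of > 30000 nM in this assay, at which 3 of the 4 values shown sit.

The compounds shown leave open whether isopropyl in place of methyl on a saturated ring carbon changes growth inhibition at all.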